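The source may hold more compounds than are shown below. What is called first, only, known or untested is meant among the compounds shown, and "the series" means these compounds.

Compound 1 `COc1cc(/C=C/c2nc(N3CCCC3)c3sccc3n2)cc(OC)c1OC` gives 681000 nM in a functional assay on L02 cells (Homo sapiens) for inhibition, read by Griess assay, with stated times of 1 h and 24 h; on this read-out lower numbers stand for stronger inhibition and higher numbers for weaker inhibition. Compound 2 `CCN1CCN(c2nc(/C=C/c3cc(OC)c(OC)c(OC)c3)nc3ccsc23)CC1` gives only a limit of the assay in this assay, > 1000000 nM. Compound 3 `COc1ccc(Nc2nc(/C=C/c3cc(OC)c(OC)c(OC)c3)nc3ccsc23)cc1` gives 279000 nM in this assay.

Among the numbers in hand, compound 3 holds the lowest one; the nearest is compound 1, which sits a step away, a 2.4-fold lower number from compound 1 to compound 3 (0.39 log units; beyond the scatter), and the remaining entry for compound 2 is a limit rather than a number (the limit of > 1000000 nM in this assay, at which 1 of the 3 values shown sits).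

Compound 4 `COc1cc(/C=C/c2nc(Nc3ccc(C(F)(F)F)cc3)c3sccc3n2)cc(OC)c1OC` is the next member. It differs from compound 3 in one place: trifluoromethyl in place of methoxy on an aromatic carbon. The measured steps all concern the group on the shared core, not the phenyl of the anilino substituent: a 2.4-fold lower number from compound 1 to compound 3 (0.39 log units; beyond the scatter), an at least 3.5-fold lower number from compound 2 to compound 3 (0.55 log units; beyond the scatter) and an at least 1.4-fold higher number from compound 1 to compound 2 (0.16 log units; that floor lies within the scatter). For the measured compounds named here, none of them exchanges a substituent on that phenyl, so no measured step bears directly on the change from compound 3 to compound 4. Going by the values given here, with no direct precedent, the expected step in this assay from compound 3 to compound 4 is a 1.1-fold higher number from compound 3 to compound 4 (0.03 log units; within the scatter), a change not clearly beyond the scatter. Compound 4 is accordingly estimated at 300000 nM, with a range from 110000 nM to 850000 nM.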

Compound 4, half-maximal inhibitory concentration: 436000 nM
For compound 4 the middle estimate is 1.5-fold (0.16 log units) below the measured one, and the stated range covers the measured number.
By their numbers in this assay, from the lowest: compounds 3, 4 and 1 (each within the scatter of the next, the first and the last beyond it). At a limit, above all of these: compound 2.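

In this assay, for the compounds shown here, this is the first exchange on the phenyl of the anilino substituent, and trifluoromethyl in place of methoxy, para to a large group, leaves the two numbers within the scatter of each other: a 1.6-fold higher number from compound 3 to compound 4 (0.19 log units; within the scatter). The separation from the pyrrolidin-1-yl compound does not carry over in full, since compound 3 stands beyond the scatter in a 2.4-fold lower number from compound 1 to compound 3 (0.39 log units; beyond the scatter), whereas the new group stays within it in a 1.6-fold lower number from compound 1 to compound 4 (0.19 log units; within the scatter). Against 4-ethylpiperazin-1-yl the new anilino group still reads beyond the scatter, an at least 2.2-fold lower number from compound 2 to compound 4 (0.36 log units; beyond the scatter), but that step rests on a value for compound 2 that is a limit and not a number: the limit of > 1000000 nM in this assay, at which 1 of the 4 values shown sits.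

Only methoxy and trifluoromethyl are shown on that phenyl, so it stays open whether a chlorine, a carboxylic acid or a primary amine in the same place would move the number beyond the scatter. Also open, going by these compounds, is how a plain phenylamino group or a morpholine would stand on the shared core in this assay.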